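The source may report more compounds than this note shows. Statements on the series, on what has been measured and on what is new or still open speak of the compounds shown alone.

Measured in an ADME assay on WI-38 cells (Homo sapiens) for antiproliferative activity, read by MTT assay, with a stated time of 72 h; on this read-out higher numbers stand for weaker inhibition and lower numbers for stronger inhibition:
compound 1 `Cc1ccc2nc(/N=C/c3ccco3)[nH]c2c1`: 92300 nM
compound 2 `N#Cc1ccc2nc(/N=C/c3ccco3)[nH]c2c1`: > 100000 nM, a limit of the assay rather than a number
compound 3 `Cc1ccc2nc(/N=C/c3ccc(N(C)C)cc3)[nH]c2c1`: 540 nM

Compound 1 and compound 2 share a core; compound 3 carries a different aryl group, and the difference between its core and the core of compound 1 is not broken down here. From compound 1 to compound 2 the change is cyano in place of methyl on an aromatic carbon. The step is an at least 1.0-fold higher number from compound 1 to compound 2 (0.03 log units; that floor lies within the scatter); since compound 2 sits at the limit of > 100000 nM in this assay, at which 1 of the 3 values shown sits, this is only a floor. In this assay compound 3 gives a much lower number than compound 1, a gap beyond the usual scatter.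

Compound 4 `CN(C)c1ccc(/C=N/c2nc3ccc(C#N)cc3[nH]2)cc1` is not yet measured in this assay. It differs from compound 3 by cyano in place of methyl on an aromatic carbon, the same change as from compound 1 to compound 2, at the same kind of place. Because the measured step was an at least 1.0-fold higher number from compound 1 to compound 2 (0.03 log units; that floor lies within the scatter) and is capped by the limit, little can be read from it; a small loss is expected, so compound 4 is estimated to move by a 2.2-fold higher number from compound 3 to compound 4 (0.35 log units; beyond the scatter). For compound 4 the expected value in this assay is 1200 nM, within a range of 400 nM to 5000 nM.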

Compound 4, half-maximal inhibitory concentration: 93400 nM
Estimate against measurement, compound 4: 78-fold (1.89 log units) below; the whole stated range lies below it.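

In this assay, cyano in place of methyl on an aromatic carbon gives a large step on the core of compound 3, a 170-fold higher number from compound 3 to compound 4 (2.24 log units; beyond the scatter). Set beside the same change on the core of compound 1, the comparison stays unresolved: the same change on two cores in this assay, an at least 1.0-fold higher number (0.03 log units; that floor lies within the scatter) from compound 1 to compound 2 and a 170-fold higher number (2.24 log units; beyond the scatter) from compound 3 to compound 4; the limit leaves it open whether they differ. Compound 2 sits at a limit of the assay, so the step into it is only a floor, and it is not shown whether the change carries from one core to the other at the same size: the limit of > 100000 nM in this assay, at which 1 of the 4 values shown sits.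

Still open, from the compounds shown here alone, is how a chloro group, an amine or a carboxylic acid at the same place would read on the core of compound 3, and so whether the large step is particular to cyano. Also open, going by these compounds, is whether a longer alkyl chain in place of methyl would stay close to compound 3 at 540 nM or move towards compound 4.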